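The compounds below may be only part of what the source reports. "The series", "measured", "known", "first", "only" and "open" are said of these compounds alone.

Measured compounds:
Compound 1, `CCCCCCCCCCCCCCCCc1nc(N2CCC2)c(C)c(C)c1O`, in a functional assay on cells (Lymphocyte, Homo sapiens), read by trypan blue exclusion, with a stated time of 16 h, tested at 0.1 uM (a higher number here means a stronger effect of the compound at the concentration tested, a lower number a weaker effect), compound 1 gives 13%.
Compound 2, `CCCCCCCCCCc1nc(N(C)C)c(C)c(C)c1O`, in this assay compound 2 gives 6%.
Compound 3, `CCCCCCCCCCCCCCCCc1c(C)c(N2CCC2)nc(C)c1O`, in this assay compound 3 gives 18%.

Among these three numbers compound 2 stands lowest. Its nearest neighbour is compound 1, whose number lies higher by an amount that is within the usual scatter, so the two cannot be told apart; its furthest is compound 3, whose number lies higher by an amount beyond the scatter. Compound 4, `CCCCCCCCCCCCCCCCc1nc(N(C)C)c(C)c(C)c1O`, has not yet been measured in this assay. It differs from compound 2 by hexyl in place of hydrogen on a saturated chain carbon, ten or more bonds along the chain from an aromatic carbon. Compound 1 and compound 3 both carry the longer chain and sit at the values given above, neither far from compound 2. Among the compounds with values here, no step between measured compounds bears on this change directly, so only a small step is expected in this assay, if any, pointing slightly upward and likely not beyond the scatter: the step from compound 2 to compound 4 is estimated at a number 6 percentage points higher from compound 2 to compound 4 (within the scatter). For compound 4 the expected value in this assay is 12%, with a range from 3% to 25%.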

Compound 4, a percentage reported as activity, at one concentration (the size of the read-out at that concentration, not a potency): 29%
For compound 4 the middle estimate is 17 percentage points below the measured one; the whole stated range lies below it.
By their numbers in this assay, from the lowest: compounds 2, 1 and 3 (each within the scatter of the next, the first and the last beyond it); then compound 4.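

In this assay, within the data shown here, hexyl in place of hydrogen on a saturated chain carbon, ten or more bonds along the chain from an aromatic carbon, gives a number 23 percentage points higher from compound 2 to compound 4 (beyond the scatter) and so provides the first direct reading of chain length at this place, with the dimethylamino group held constant. With the long chain held constant, dimethylamino in place of azetidin-1-yl on an aromatic carbon gives a number 16 percentage points higher from compound 1 to compound 4 (beyond the scatter) and shows that the amine group also bears on the read-out. No measurement is available to explain either step.

The compounds shown leave open whether a longer chain than that of compound 4 would go with a higher or a lower number. They also leave open how a piperidin-1-yl group in place of dimethylamino would compare.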